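This account rests on a few compounds, and the source may have more. Where it says the series, first, only, none or still open, it means among the compounds named here.

Measured so far in an ADME assay on microsomes from liver (Homo sapiens) for metabolic stability; on this read-out lower numbers stand for slow clearance and higher numbers for fast clearance:
compound 1 `CCNc1[nH]c(=O)n(O)c(=O)c1C(=O)NCc1ccccc1` — < 0.1 uL/min
compound 2 `CCNc1[nH]c(=O)n(O)c(=O)c1C(=O)NCc1ccc(F)cc1` — < 0.1 uL/min

In this assay compound 1 gives < 0.1 uL/min, which is a limit of the assay rather than a number. In this assay compound 2 likewise gives < 0.1 uL/min, also a limit. Within the data shown here, both values sit at the limit of < 0.1 uL/min in this assay, at which 2 of the 2 values shown sit, so the step that the two limits leave unreadable from compound 1 to compound 2 cannot be read from the two values; it is the only measured step. Compound 2 therefore stands at the limit, with no number behind it.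

Compound 3 `CCNc1[nH]c(=O)n(O)c(=O)c1C(=O)NCc1ccc(C)c(F)c1` is not yet measured in this assay. It differs from compound 2 by 3-fluoro-4-methylphenyl in place of 4-fluorophenyl on a saturated chain carbon bound to an amide-type nitrogen. Among the measured compounds shown here, no measured step of readable size bears on this change. The expected step is a number no lower from compound 2 to compound 3 (the limit leaves the size open) in this assay, with the result most likely again only a limit. Compound 3 is estimated at 0.1 uL/min, with a range from 0.04 uL/min to 0.4 uL/min.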

Compound 3, intrinsic clearance in a liver preparation (reported as CLH), per the amount of preparation that the assay uses in the Homo sapiens assay: < 0.1 uL/min
Compound 3 ended at the assay's limit (the forecaster's own chance of this, stated with the estimate: 70%); the middle value lies on the limit itself.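

In a physicochemical assay for pharmacokinetics (a lower number here means that the compound disappears faster, a higher number that the compound lasts longer), compound 2 gives > 24 h, a limit of the assay. In the physicochemical assay compound 3 gives > 24 h, also a limit. Among these compounds, no step among compound 1, compound 2 and compound 3 can be read in either read-out. Going by these compounds, how far each compound lies beyond these limits stays open.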